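A few compounds are considered here, and "the series" means these few. Any claim that something is new, unique, unknown or untested is made for them only; others in the source may bear on it.

Compound 1 `COC(=O)CNC(=O)NCc1ccc(C(=O)N2CCCCc3ccccc32)cc1C` is the lower of the two numbers in hand: in a functional assay on HEK293 cells for agonist activity at Vasopressin V2 receptor (Homo sapiens), read by a luciferase reporter and cAMP accumulation (a lower number here means that less compound is needed, a higher number that more compound is needed for the effect), compound 1 gives 37 nM, whereas compound 2 `Cc1cc(C(=O)N2CCCCc3ccccc32)ccc1CNC(=O)N1CCC[C@H]1C(=O)O` gives 680 nM. Compound 3 `Cc1cc(C(=O)N2CCCCc3ccccc32)ccc1CNC(=O)N1CCC[C@H]1C(=O)OC(C)(C)C` differs from compound 1 by 2-(tert-butoxycarbonyl)pyrrolidin-1-yl in place of ((methoxycarbonyl)methyl)amino on a carbonyl carbon. Among the measured compounds shown here, the only step that bears on it is an 18-fold higher number from compound 1 to compound 2 (1.26 log units; beyond the scatter), where the same pyrrolidine ring entered with a free acid; compound 3 instead carries an ester, as compound 1 does. A weakening smaller than that step is therefore expected, namely a 5.4-fold higher number from compound 1 to compound 3 (0.73 log units; beyond the scatter). Compound 3 is estimated at 200 nM, with a range from 60 nM to 700 nM.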

Compound 3, half-maximal effective concentration: 390 nM
For compound 3 the middle estimate is 2.0-fold (0.29 log units) below the measured one, and the stated range covers the measured number.
By their numbers in this assay, from the lowest: compound 1; then compounds 3 and 2 (each within the scatter of the next).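

In this assay, the ester on the pyrrolidine ring does not recover what the free acid lost: the change from the open chain gives an 11-fold higher number from compound 1 to compound 3 (1.02 log units; beyond the scatter), while tert-butyl in place of hydrogen gives only a 1.7-fold lower number from compound 2 to compound 3 (0.24 log units; within the scatter). At this carbonyl carbon, then, both ring compounds stand apart from compound 1, whether they carry the acid or the ester. No measurement available here accounts for this. Still open, on these data alone, is whether a methyl ester on the same pyrrolidine ring, or a pyrrolidine with no carboxyl group at all, would behave likewise.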